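Acetylation of the hydroxypropyl chain in compound 2

The compounds below may be only part of what the source reports. "The series", "measured", "known", "first", "only" and "open" are said of these compounds alone.

Compound 2 `O=C1c2ccccc2C(OCCCO)(c2ccc(Cl)cc2)N1Cc1ccccc1` carries a free hydroxy group at the end of its chain on the core. In a functional assay on HCT-116 cells (Homo sapiens) for inhibition, read by fluorescence, with a stated time of 48 h (a lower number here means a stronger inhibitor of growth, a higher number a weaker inhibitor of growth), compound 2 gives 79000 nM, the highest number of the two measured. Compound 1 `N[C@H](C(=O)OCCCOC1(c2ccc(Cl)cc2)c2ccccc2C(=O)N1Cc1ccc(Cl)cc1)c1ccccc1`, an ester on the same chain, gives 12000 nM, a lower number beyond the scatter. Compound 3 `CC(=O)OCCCOC1(c2ccc(Cl)cc2)c2ccccc2C(=O)N1Cc1ccccc1` is the acetyl ester of compound 2; the change is acetyl in place of hydrogen on an oxygen on a saturated carbon. Going by the values given here, no measured pair isolates this change; the ester compound 1 at 12000 nM suggests the number is expected to fall, perhaps beyond the scatter. Compound 3 is expected near 30000 nM (range 10000 nM to 90000 nM). The expected step is a 2.6-fold lower number from compound 2 to compound 3 (0.42 log units; beyond the scatter).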

Compound 3, concentration for 50% growth inhibition: 50000 nM
Compound 3: the middle estimate sits 1.7-fold (0.22 log units) below what was measured; measured number inside the range.
By their numbers in this assay, from the lowest: compound 1; then compounds 3 and 2 (each within the scatter of the next).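

In this assay, going by these compounds alone, acetyl in place of hydrogen on the oxygen at the chain end gives a 1.6-fold lower number from compound 2 to compound 3 (0.20 log units; within the scatter) and so provides the first comparison that differs in one place only. At this position, the free hydroxy can therefore be replaced by acetoxy without a change beyond the scatter. No measured evidence bears on why the two compounds fall so close. Still open, on these data alone, is whether an amine or a carboxylic acid at the chain end would separate from compound 2 beyond the scatter. As far as these compounds go, the effect of a longer chain also remains open.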